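A few compounds are considered here, and "the series" means these few. Any claim that something is new, unique, unknown or untested is made for them only; others in the source may bear on it.

Compound 1 `C=CCn1c(=O)/c(=C\c2ccccc2Cl)[nH]c(=O)/c1=C\c1ccccc1OC` gives 2500 nM as its value
Compound 2 `COc1ccccc1/C=c1\c(=O)[nH]/c(=C/c2cccc(Cl)c2Cl)c(=O)n1C` gives 110 nM as its value

In a functional assay on K562 cells (Homo sapiens) for cytotoxicity, read by CCK-8 assay, with a stated time of 72 h (on this read-out higher numbers stand for weaker inhibition and lower numbers for stronger inhibition), compound 2 at 110 nM is the lower of the two numbers, and compound 1 at 2500 nM lies higher by more than the scatter. Compound 3 `COc1ccccc1/C=c1\c(=O)[nH]/c(=C/c2ccccc2Cl)c(=O)n1C` has not yet been measured. It differs from compound 2 in one place (hydrogen in place of chloro on an aromatic carbon) with hydrogen in place of chloro on an aromatic carbon, so 2,3-dichlorophenyl becomes 2-chlorophenyl. Going by the values given here, no measured pair shows this change alone, so the expectation is a loose one. A moderate rise in the number is expected, towards weaker inhibition and probably somewhat beyond the scatter. The expected step runs a 3.2-fold higher number from compound 2 to compound 3 (0.50 log units; beyond the scatter) and remains only an estimate. The estimate for compound 3 is 350 nM with an expected range from 100 nM to 1500 nM in this assay when it is measured.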

Compound 3, half-maximal inhibitory concentration: 110 nM
Compound 3: the middle estimate sits 3.2-fold (0.50 log units) above what was measured, and the stated range covers the measured number.
By their numbers in this assay, from the lowest: compounds 2 and 3 (each within the scatter of the next); then compound 1.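

In this assay, replacing the chloro group with hydrogen, so that 2,3-dichlorophenyl becomes 2-chlorophenyl, gives no change at the digits printed from compound 2 to compound 3 (within the scatter), which shows that this aromatic carbon carries either group with no change beyond the scatter. With the 2-chlorophenyl group held constant, hydrogen in place of vinyl on the saturated chain carbon bound to the aromatic nitrogen gives a 23-fold lower number from compound 1 to compound 3 (1.36 log units; beyond the scatter), placing a large step at that chain rather than at the chloro position. No measurement offered here accounts for either step.

The compounds shown leave open whether a fluoro, amine or carboxylic acid group on this aromatic carbon would also leave the number in this assay unchanged. They also leave open how an ethyl group or a longer chain on the aromatic nitrogen would compare.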